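Heteroaryl swap at the aminomethyl arm of compound 3

This account rests on a few compounds, and the source may have more. Where it says the series, first, only, none or still open, it means among the compounds named here.

Measured in an assay for inhibition of Caspase-8 (Homo sapiens); on this read-out lower numbers stand for stronger inhibition and higher numbers for weaker inhibition:
Compound 2 `CCC(C(=O)N[C@@H](CC(=O)O)C(=O)CSCc1ccccc1)n1ccnc(NCc2cccs2)c1=O`: 2090 nM
Compound 3 `CCC(C(=O)N[C@@H](CC(=O)O)C(=O)CSCc1ccccc1)n1ccnc(NCc2cncs2)c1=O`: 6590 nM
Compound 1 `CCCCCCN(C)CNCC(=O)[C@H](CC(=O)O)NC(=O)C(CC)n1cc(C(C)(CC)CC)nc(NCc2nonc2C)c1=O`: > 10000 nM, which is a limit of this assay and not a number.

Within the data shown here, compound 3 holds the highest of the two numbers; its nearest neighbour is compound 2, and the one measured step, a 3.2-fold higher number from compound 2 to compound 3 (0.50 log units; beyond the scatter), is the only guide here. Compound 4 `CCC(C(=O)N[C@@H](CC(=O)O)C(=O)CSCc1ccccc1)n1ccnc(NCc2nc(C)no2)c1=O` carries the change (3-methyl-1,2,4-oxadiazol-5-yl in place of 1,3-thiazol-5-yl on a saturated chain carbon bound to a nitrogen on an aromatic ring). Among the measured compounds shown here, no measured step covers this exact swap, and compound 1, with its own oxadiazole, sits at a limit of > 10000 nM in this assay, at which 1 of the 3 values shown sits, and is altered in several other places. A small further weakening, or none beyond the scatter, is therefore expected. Compound 4 is estimated at 9000 nM in this assay, between 3000 nM and 27000 nM, meaning a 1.4-fold higher number from compound 3 to compound 4 (0.14 log units; within the scatter).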

Compound 4, half-maximal inhibitory concentration: 6420 nM
Compound 4: middle estimate off by 1.4-fold (0.15 log units), on the high side; low and high end bracket the measured number.
By their numbers in this assay, from the lowest: compound 2; then compounds 4 and 3 (each within the scatter of the next). At a limit, above all of these: compound 1.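

In this assay, the step of a 1.0-fold lower number from compound 3 to compound 4 (0.01 log units; within the scatter) shows that 3-methyl-1,2,4-oxadiazol-5-yl and 1,3-thiazol-5-yl are not told apart at this position, even though the two groups differ in hetero atoms and size. The step of a 3.1-fold higher number from compound 2 to compound 4 (0.49 log units; beyond the scatter) shows that a second group, now with a different ring, also gives a higher number than thiophen-2-yl. Nothing measured here accounts for either step.

From the compounds shown here alone, whether a furan-2-yl or a phenyl group at this position would match compound 2 remains open. So does whether the thiophen-2-yl advantage would persist with an amine in place of the benzylsulfanyl part.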